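Five-membered heteroaryl exchange: compound 1 to compound 3

The source may report more compounds than this note shows. Statements on the series, on what has been measured and on what is new or still open speak of the compounds shown alone.

Measured compounds:
compound 1 `Cc1noc(C)c1-c1cnc(N)c(Oc2ccc(C(=O)Nc3ccc(Cl)cc3)cc2)n1`: 1920 nM
compound 2 `Cc1noc(C)c1-c1cnc(N)c(Oc2ccc(C(=O)Nc3cccc(Cl)c3)cc2)n1`: 1640 nM

In a functional assay on LoVo cells (Homo sapiens) for inhibition, read by MTT assay, with a stated time of 72 h (on this read-out lower numbers stand for stronger inhibition and higher numbers for weaker inhibition), compound 1 gives 1920 nM, the highest of the two numbers. Compound 2 gives 1640 nM, and a 1.2-fold lower number from compound 1 to compound 2 (0.07 log units; within the scatter) lies within the scatter. Compound 3 `Cn1cc(-c2cnc(N)c(Oc3ccc(C(=O)Nc4ccc(Cl)cc4)cc3)n2)cn1` carries 1-methyl-1H-pyrazol-4-yl in place of 3,5-dimethyl-1,2-oxazol-4-yl on an aromatic carbon. Among the compounds with values here, the only measured step concerns the chlorophenyl on the amide-type nitrogen, a different position, so no measured step bears on this exchange; no shift beyond the scatter is assumed, and the uncertainty is wide. Compound 3 is expected at 2500 nM, range 800 nM to 8000 nM. The expected step is a 1.3-fold higher number from compound 1 to compound 3 (0.11 log units; within the scatter).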

Compound 3, half-maximal inhibitory concentration: 3080 nM
Estimate against measurement, compound 3: 1.2-fold (0.09 log units) below; the measured number falls inside the stated range.
By their numbers in this assay, from the lowest: compounds 2, 1 and 3 (each within the scatter of the next).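

In this assay, 1-methyl-1H-pyrazol-4-yl in place of 3,5-dimethyl-1,2-oxazol-4-yl on the aromatic carbon gives a 1.6-fold higher number from compound 1 to compound 3 (0.21 log units; within the scatter). This carbon of the shared core therefore takes either of these two five-membered aromatic rings with no shift beyond the scatter, which the chlorophenyl step could not show. No available evidence bears on this result.

Still open, as far as these compounds go, is whether a pyridin-4-yl ring, a primary amine or a carboxylic acid on this carbon would move the number beyond the scatter. Also open, from the compounds shown here alone, is how 1-methyl-1H-pyrazol-4-yl behaves alongside the 3-chlorophenyl amide of compound 2.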